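Furan-for-thiophene swap on the amine nitrogen of the core

The compounds below may be only part of what the source reports. "The series", "measured", "known", "first", "only" and "open" are said of these compounds alone.

Compound 1 `CCCN(c1nccc(-c2c(OC)cc(OC)cc2OC)n1)C(C1CC1)C1CC1` is the reference point for this set. In an assay on CHO cells for displacement of a labelled ligand from corticotropin-releasing factor receptor 1 (Homo sapiens) (a lower number here means a stronger inhibitor, a higher number a weaker inhibitor), compound 1 gives 15 nM, the lowest of the three numbers measured. Compound 2 `CCCN(c1nccc(-c2c(OC)cc(OC)cc2OC)n1)[C@@H](c1ccccc1)C1CC1` gives 240 nM and compound 3 `CCCN(c1nccc(-c2c(OC)cc(OC)cc2OC)n1)C1(c2ccsc2)CC1` gives 2000 nM; the step of a 16-fold higher number from compound 1 to compound 2 (1.20 log units; beyond the scatter) is large and the step of a 130-fold higher number from compound 1 to compound 3 (2.12 log units; beyond the scatter) is larger still, while an 8.3-fold higher number from compound 2 to compound 3 (0.92 log units; beyond the scatter) is modest.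

Compound 4 `CCCN(c1nccc(-c2c(OC)cc(OC)cc2OC)n1)C1(c2ccoc2)CC1` has not yet been measured. The change from compound 1 is 1-(furan-3-yl)cyclopropyl in place of dicyclopropylmethyl on a nitrogen on an aromatic ring. Going by the values given here, the closest measured step is the one in which compound 3 arises from compound 1, a 130-fold higher number from compound 1 to compound 3 (2.12 log units; beyond the scatter), where a 1-(thiophen-3-yl)cyclopropyl group replaces dicyclopropylmethyl at the same nitrogen; the furan analogue here differs only in the five-membered aromatic ring. The step to compound 2, a 16-fold higher number from compound 1 to compound 2 (1.20 log units; beyond the scatter), points the same way.

A large rise in this assay is therefore expected for compound 4, estimated as a 100-fold higher number from compound 1 to compound 4 (2.00 log units; beyond the scatter), because compound 3 showed a 130-fold higher number from compound 1 to compound 3 (2.12 log units; beyond the scatter). Compound 4 is expected to give about 1500 nM, within roughly 400 nM to 6000 nM.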

Compound 4, inhibition constant: 700 nM
Compound 4: middle estimate off by 2.1-fold (0.33 log units), on the high side; measured number inside the range.
By their numbers in this assay, from the lowest: compound 1; then compound 2; then compound 4; then compound 3.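

In this assay, the five-membered aromatic ring on the cyclopropyl group affects the result: furan-3-yl in place of thiophen-3-yl gives a 2.9-fold lower number from compound 3 to compound 4 (0.46 log units; beyond the scatter), a modest step. This gain remains small beside a 47-fold higher number from compound 1 to compound 4 (1.67 log units; beyond the scatter), so neither ring comes close to dicyclopropylmethyl on this nitrogen, and the furan group also falls short of cyclopropyl(phenyl)methyl, with a 2.9-fold higher number from compound 2 to compound 4 (0.46 log units; beyond the scatter). Nothing available explains the difference between furan and thiophene here.

From the compounds shown here alone, it remains open whether a furan-2-yl or pyridin-3-yl group on the same cyclopropyl ring would lower the number further, and whether a plain phenyl group there would sit nearer compound 2 or compound 4. Going by these compounds, it is also open whether a butyl chain in place of the propyl chain on this nitrogen would change the size of these steps.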